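The source may hold more compounds than are shown below. What is called first, only, known or untested is meant among the compounds shown, and "the series" means these compounds.

Measured in a functional assay on U-373MG ATCC cells (Homo sapiens) for inhibition, read by MTT assay, with a stated time of 72 h; a higher number here means a weaker inhibitor, a lower number a stronger inhibitor:
- compound 1 `CC1(C)CC(NC(=S)Nc2ccc(C#N)cc2)c2cc(Cl)ccc2O1` gives 10000 nM
- compound 2 `CCNC(=S)NC1CC(C)(C)Oc2ccc(Cl)cc21` gives 96000 nM
- compound 3 `CC1(C)CC(NC(=S)NCc2ccccc2)c2cc(Cl)ccc2O1` gives 64000 nM

Compound 2 sits with compound 3 at the weak end of this small set, and the two cannot be told apart (a 1.5-fold lower number from compound 2 to compound 3 (0.18 log units; within the scatter)). Compound 1 is the strongest of the three, and compound 2 lies clearly away from it (a 9.6-fold higher number from compound 1 to compound 2 (0.98 log units; beyond the scatter)).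

Compound 4 `CCOC(=O)NC1CC(C)(C)Oc2ccc(Cl)cc21` keeps the shared core of compound 2 but alters what sits on the amine nitrogen. The change is a group of 5 heavy atoms (3 carbon, 2 oxygen; no ring) in place of a group of 5 heavy atoms (3 carbon, 1 nitrogen, 1 sulfur; no ring), on an amine nitrogen and the group that enters is ethoxycarbonyl. Among the compounds with values here, no measured pair makes this swap, so the evidence is indirect. The nearest guides are changes to the group on the amide-type nitrogen. Two of these were modest (a 9.6-fold higher number from compound 1 to compound 2 (0.98 log units; beyond the scatter) and a 6.4-fold higher number from compound 1 to compound 3 (0.81 log units; beyond the scatter)), and both start from the 4-cyanophenyl compound. Compound 4 has no 4-cyanophenyl group, and the two measured compounds without one stay close together (a 1.5-fold lower number from compound 2 to compound 3 (0.18 log units; within the scatter)). The data give no direction for the new swap, so no step beyond the scatter is expected in this assay, although a modest one either way remains possible. The estimated step is small (a 1.2-fold lower number from compound 2 to compound 4 (0.08 log units; within the scatter)). For compound 4 the expected value is 80000 nM with an estimated range from 30000 nM to 200000 nM in this read-out.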

Compound 4, half-maximal inhibitory concentration: > 100000 nM
Compound 4: a limit, no number; the forecaster's own chance of this, stated with the estimate: 15%; middle value at least 1.2-fold (0.09 log units) from the limit.
By their numbers in this assay, from the lowest: compound 1; then compounds 3 and 2 (each within the scatter of the next). At a limit, above all of these: compound 4.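

Within the data shown here, compound 4 is the first compound here without the sulfur-bearing group on the amine nitrogen, whereas compounds 1, 2 and 3 all keep that group and vary only what sits on its amide-type nitrogen. In this assay compound 4 gives > 100000 nM, which is a limit of the assay and not a number. With ethoxycarbonyl on the amine nitrogen, the result shows no sign of stronger inhibition than compound 2, but the step is only a floor, an at least 1.0-fold higher number from compound 2 to compound 4 (0.01 log units; that floor lies within the scatter), and its true size cannot be read because the value is a limit: the limit of > 100000 nM in this assay, at which 1 of the 4 values shown sits.

The swap changes several things at once, replacing a nitrogen and a sulfur with two oxygens and removing the hydrogen-bond donor counted in the group that leaves, so the compounds shown cannot say which of these differences matters. A urea that keeps the ethyl group and the nitrogen but has a carbonyl oxygen in place of the sulfur would separate the loss of sulfur from the loss of that nitrogen, and a 4-cyanophenyl carbamate would test the oxygen-bearing link with a different group attached.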